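A few compounds are considered here, and "the series" means these few. Any claim that something is new, unique, unknown or untested is made for them only; others in the source may bear on it.

Measured in a functional assay on HeLa cells (Homo sapiens) for antiproliferative activity, read by MTT assay, with a stated time of 48 h; a higher number here means a weaker inhibitor, a lower number a stronger inhibitor:
- compound 1 `COc1cc(-c2nnc3c(OCC(F)(F)F)cc(-c4ccc5[nH]ccc5c4)cn23)cc(OC)c1OC`: 348 nM
- compound 2 `COc1cc(-c2nnc3c(OC)cc(-c4ccc5c(ccn5C)c4)cn23)cc(OC)c1OC`: 15 nM
- compound 3 `COc1cc(-c2nnc3c(OCC(F)(F)F)cc(-c4ccc5c(ccn5C)c4)cn23)cc(OC)c1OC`: 199 nM

Compound 3 belongs to the upper pair of these numbers, as the measured steps show: a 1.7-fold lower number from compound 1 to compound 3 (0.24 log units; within the scatter), and a 13-fold higher number from compound 2 to compound 3 (1.12 log units; beyond the scatter). Compound 4 `CCCN1CC(Oc2cc(-c3ccc4c(ccn4C)c3)cn3c(-c4cc(OC)c(OC)c(OC)c4)nnc23)C1` carries 1-propylazetidin-3-yl in place of 2,2,2-trifluoroethyl on an oxygen on an aromatic ring. Only the second step changes the group on that oxygen, and its large size shows that this group can matter. Going by the values given here, it gives no direction for the new group, which no measured compound carries, while the first step lies elsewhere in the structure. The estimated step is a 1.3-fold lower number from compound 3 to compound 4 (0.12 log units; within the scatter), so no change beyond the scatter is expected in this assay. For compound 4 the expected value is 150 nM, within an estimated range of 30 nM to 700 nM.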

Compound 4, half-maximal inhibitory concentration: 211 nM
The estimate for compound 4 lay 1.4-fold (0.15 log units) below the measured number; measured number inside the range.
By their numbers in this assay, from the lowest: compound 2; then compounds 3, 4 and 1 (each within the scatter of the next).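

In this assay, putting 1-propylazetidin-3-yl on the oxygen in place of 2,2,2-trifluoroethyl leaves the number within the scatter (a 1.1-fold higher number from compound 3 to compound 4 (0.03 log units; within the scatter)). Its step from methyl is large (a 14-fold higher number from compound 2 to compound 4 (1.15 log units; beyond the scatter)), so this second, quite different group also stands well apart from methyl at this position. Nothing available here explains this result. On these data alone, it remains open whether an ethyl group on that oxygen, or an azetidine without the propyl chain, would give a number close to that of methyl or close to those of these two larger groups.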